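Swapping an aromatic tail for a branched alkyl

The compounds below may be only part of what the source reports. "The series", "measured", "known", "first", "only" and "open" are said of these compounds alone.

Compound 1 `CCCCc1cnc(C(C)Cc2ccc(-c3ccccc3C(=O)O)cc2)[nH]1` gives 2760 nM in an in vitro functional assay on cells for agonist activity at Bombesin receptor subtype-3 (Homo sapiens), read by luminescence and calcium flux; a lower number here means that less compound is needed, a higher number that more compound is needed for the effect.
Compound 2 `COc1ccc(Cc2cnc(CCc3ccc(-c4ccccc4C(=O)O)cc3)[nH]2)cc1` gives 5360 nM in this assay.
Compound 3 `CCCCc1cnc(C(CC)Cc2ccc(-c3ccccc3C(=O)O)cc2)[nH]1` gives 2720 nM in this assay.

Compound 2 has the highest of the three numbers, yet its gaps to compound 1 and to compound 3 both lie within the usual scatter, so no order among the three can be read from them. Compound 4 `CCC(C)(CC)Cc1cnc(CCc2ccc(-c3ccccc3C(=O)O)cc2)[nH]1` differs from compound 2 by 1-ethyl-1-methylpropyl in place of 4-methoxyphenyl on a saturated chain carbon bound to an aromatic carbon. Among the measured compounds shown here, the only measured step, a 1.0-fold lower number from compound 1 to compound 3 (0.01 log units; within the scatter), concerns a different place and was flat, so it says little here. What does bear on the change is that compounds 1 and 3, whose corresponding group is a plain alkyl chain rather than an aromatic ring, sit within the scatter of compound 2. A shift in this assay toward slightly lower numbers is therefore plausible, but nothing beyond the scatter is expected. Compound 4 is expected to give about 3000 nM, with a range from 1000 nM to 9000 nM. That estimate means a step of a 1.8-fold lower number from compound 2 to compound 4 (0.25 log units; within the scatter), expected to stay within the scatter.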

Compound 4, half-maximal effective concentration: 76 nM
Compound 4: the middle estimate sits 39-fold (1.60 log units) above what was measured; measured number outside the range, below it.
By their numbers in this assay, from the lowest: compound 4; then compounds 3, 1 and 2 (each within the scatter of the next).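

At this place, on a saturated chain carbon bound to an aromatic carbon, the choice of group can matter greatly: in this assay, putting 1-ethyl-1-methylpropyl in place of 4-methoxyphenyl gives a 71-fold lower number from compound 2 to compound 4 (1.85 log units; beyond the scatter), the only step shown that lies beyond the scatter. An aromatic ring at this place is therefore not required for a low number, since the group in compound 4 has no ring and still needs far less compound than the 4-methoxyphenyl group in compound 2. No measurement shown explains why this change has so large an effect.

The change removes the ring and the methoxy oxygen and introduces branching all at once, so the compounds shown cannot say which of these matters. Unsubstituted phenyl and an unbranched hexyl chain at this place would help separate them.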